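This account rests on a few compounds, and the source may have more. Where it says the series, first, only, none or still open, it means among the compounds named here.

Measured so far in an assay on isolated protein for binding affinity to Alpha-1D adrenergic receptor (Rattus norvegicus), read by radioligand binding; on this read-out higher numbers stand for weaker inhibition and lower numbers for stronger inhibition:

Compound 1 `CC(C)S(=O)(=O)Nc1cccc2c1CCCC2c1c[nH]cn1`: 2040 nM
Compound 2 `O=S(=O)(Nc1cccc2c1CCCC2c1c[nH]cn1)C1CC1`: 2690 nM

Compound 1 gives the lower of the two numbers, but its nearest neighbour is compound 2, and that pair shows a 1.3-fold higher number from compound 1 to compound 2 (0.12 log units; within the scatter), so the two compounds cannot be told apart on these data. The measured step changes only the group carried by the sulfonyl sulfur and keeps the sulfonamide itself.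

Compound 3 `O=C(Nc1cccc2c1CCCC2c1c[nH]cn1)C(F)(F)F` has not yet been measured. It differs from compound 1 in one place: (trifluoromethyl)carbonyl in place of isopropylsulfonyl on a nitrogen on an aromatic ring. The shared core is untouched; what changes is the group on the ring nitrogen, a sulfonyl giving way to a carbonyl bearing three fluorines. Going by the values given here, the one measured step bears on this only loosely: it shows that varying the group beyond the sulfur hardly moved the number, yet no measured pair exchanges the sulfonyl for a carbonyl, so the direction of this step is not fixed by anything measured.

The expected change from compound 1 to compound 3 is therefore a 1.5-fold higher number from compound 1 to compound 3 (0.17 log units; within the scatter), a step not clearly beyond the scatter. Compound 3 is estimated at 3000 nM. For compound 3 the expected range runs from 800 nM to 12000 nM.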

Compound 3, inhibition constant: 3310 nM
For compound 3 the middle estimate is 1.1-fold (0.04 log units) below the measured one; the range from low to high includes it.
By their numbers in this assay, from the lowest: compounds 1, 2 and 3 (each within the scatter of the next).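

In this assay, the earlier pair varied only the group beyond the sulfur, whereas this result replaces the sulfonyl itself: the exchange gives a 1.6-fold higher number from compound 1 to compound 3 (0.21 log units; within the scatter) and, starting from the cyclopropyl compound, a 1.2-fold higher number from compound 2 to compound 3 (0.09 log units; within the scatter) and so neither step can be told from repeat-measurement noise. At this position on the ring nitrogen, (trifluoromethyl)carbonyl therefore cannot be distinguished from isopropylsulfonyl or cyclopropylsulfonyl, even though the entering group has no sulfur, brings in three fluorines, and has 1 hydrogen-bond acceptor where the leaving group has 2. The sulfonyl is thus not needed to keep the number in this range, at least among these three compounds.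

Since the carbonyl and the trifluoromethyl arrive together, these compounds cannot separate the two, and an acetyl group, which has the carbonyl without the fluorines, would be the natural comparison; a free amino group or a benzoyl group would show whether the nitrogen tolerates much larger or smaller changes. No supporting measurement is available to explain why these numbers lie so close together.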